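The source may hold more compounds than are shown below. What is called first, only, known or untested is meant among the compounds shown, and "the series" means these compounds.

Compound 2, with the structure `COc1ccc(-c2csc(N)c2C(=O)NCc2ccccc2)cc1OC`, gives 43% in an assay on isolated protein for inhibition of protein kinase C zeta type (Homo sapiens), with stated times of 1 h and 2.5 min, tested at 30 uM; a lower number here means less inhibition, a higher number more inhibition at the concentration tested (going by the name of the read-out). Compound 1, with the structure `COc1ccc(-c2csc(N)c2C(=O)OCc2ccc(F)cc2)cc1OC`, gives 2% in this assay. Within the data shown here, of the two numbers measured so far, compound 2 stands highest, and the only measured step, a number 41 percentage points higher from compound 1 to compound 2 (beyond the scatter), is a large one that concerns the group on the carbonyl carbon.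

Compound 3, with the structure `COc1ccc(-c2csc(N)c2C(=O)NCc2ccncc2)cc1OC`, has not yet been tested. It differs from compound 2 by pyridin-4-yl in place of phenyl on a saturated chain carbon bound to an amide-type nitrogen. Among the measured compounds shown here, the single measured step changed a different part of the molecule, so no measured step bears directly on swapping one six-membered aromatic ring for another at this place. Without such a comparison, the expectation for compound 3 is a value close to that of compound 2, with a step of a number 5 percentage points lower from compound 2 to compound 3 (within the scatter) that is estimated to stay within the scatter. Compound 3 is therefore expected to give about 38% in this assay, in a range from 15% to 60%.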

Compound 3, a percentage reported as inhibition, at one concentration (the size of the read-out at that concentration, not a potency): 3%
Compound 3: the middle estimate sits 35 percentage points above what was measured, outside the stated range (below it).
By their numbers in this assay, from the lowest: compounds 1 and 3 (each within the scatter of the next); then compound 2.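

Within the shared core, this position is sensitive to a small change: pyridin-4-yl in place of phenyl on the saturated chain carbon bound to the amide-type nitrogen, which exchanges one ring carbon for one nitrogen and keeps the count of heavy atoms, gives a number 40 percentage points lower from compound 2 to compound 3 (beyond the scatter) in this assay. With ((pyridin-4-yl)methyl)amino in place of (4-fluorobenzyl)oxy on the carbonyl carbon, the step is only a number 1 percentage points higher from compound 1 to compound 3 (within the scatter), so the large gain seen with benzylamino does not extend to this second amino group. Nothing available here explains why this single ring change matters so much.

The compounds shown leave open how other rings fare at this place, such as pyridin-3-yl, 4-fluorophenyl or cyclohexyl. They also leave open what a longer chain, such as 2-phenylethyl, would give in place of benzyl.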